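A few compounds are considered here, and "the series" means these few. Any claim that something is new, unique, unknown or untested is made for them only; others in the source may bear on it.

Compound 1 `COC1=C(OC)[C@@]2(OC)c3c(OC)c(OC)c4c(c3O[C@@]23O[C@@H](c2ccccc2)CC=C3C1=O)[C@@H](OC)C[C@H](c1ccccc1)O4` gives 0.4 ug/mL in a functional assay on A-431 cells (Homo sapiens) for cytotoxicity (a lower number here means that less compound is needed, a higher number that more compound is needed for the effect), and compound 2 `COC1=C(OC)[C@@]2(OC)c3c(O)c(OC)c4c(c3O[C@@]23O[C@@H](c2ccccc2)CC=C3C1=O)[C@@H](OC)C[C@H](c1ccccc1)O4` gives 1 ug/mL, the highest of the two numbers; the step of a 2.5-fold higher number from compound 1 to compound 2 (0.40 log units; beyond the scatter) lies beyond the scatter. Compound 3 `COC1=C(OC)[C@@]2(OC)c3c(O)c(OC)c4c(c3O[C@@]23O[C@@H](c2ccccc2)CC=C3C1=O)[C@@H](O)C[C@H](c1ccccc1)O4` differs from compound 2 by hydrogen in place of methyl on an oxygen on a saturated carbon, methoxy to hydroxy at a second site. For the measured compounds named here, only the step from compound 1 to compound 2 bears on this change, and it was modest; a further modest rise is therefore expected, a 1.8-fold higher number from compound 2 to compound 3 (0.26 log units; within the scatter). The estimate for compound 3 is 1.8 ug/mL, between 0.8 ug/mL and 4 ug/mL.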

Compound 3, half-maximal effective concentration: 0.2 ug/mL
Estimate against measurement, compound 3: 9.0-fold (0.95 log units) above; measured number below the stated range.
By their numbers in this assay, from the lowest: compounds 3 and 1 (each within the scatter of the next); then compound 2.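

In this assay, hydrogen in place of methyl on an oxygen on a saturated carbon gives a 5.0-fold lower number from compound 2 to compound 3 (0.70 log units; beyond the scatter), whereas the same exchange on an oxygen on an aromatic ring gives a 2.5-fold higher number from compound 1 to compound 2 (0.40 log units; beyond the scatter). The same exchange thus moves the number in opposite directions at these two sites, so the earlier step did not carry over to this position. Nothing available explains this reversal. The compounds shown leave open how an amine or an acetate ester on this saturated carbon would read.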